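This account rests on a few compounds, and the source may have more. Where it says the series, first, only, none or still open, it means among the compounds named here.

Compound 1 `O=c1c(O)c(O)oc2ccc(Cl)cc12` is measured in a functional assay on the whole organism for inhibition, with Homo sapiens as the target (a higher number here means a weaker inhibitor, a lower number a stronger inhibitor), where compound 1 gives 513000 nM. Compound 2 `O=C1C(O)=C(O)OC12CCCC2` reaches only a limit of this assay, and compound 2 gives > 4000000 nM. Going by the values given here, of the two values shown, that of compound 1 is the only true number, the other being the limit (the limit of > 4000000 nM in this assay, at which 1 of the 2 values shown sits). Compound 3 `O=c1c(O)c(O)oc2ccc(O)cc12` has not yet been measured; it differs from compound 1 by hydroxy in place of chloro on an aromatic carbon. Among the compounds with values here, no measured pair shows this change, so the step of a 1.4-fold higher number from compound 1 to compound 3 (0.13 log units; within the scatter) is expected to be small, hardly beyond the scatter. Compound 3 is estimated at 700000 nM, with a range from 250000 nM to 2500000 nM.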

Compound 3, half-maximal inhibitory concentration: 1520000 nM
Compound 3: middle estimate off by 2.2-fold (0.34 log units), on the low side, and the stated range covers the measured number.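

In this assay, putting hydroxy in place of chloro on this aromatic carbon gives a 3.0-fold higher number from compound 1 to compound 3 (0.47 log units; beyond the scatter) and so a weaker inhibitor. Going by these compounds alone, this is the first single change that can be read, and it shows that the group on this carbon matters, with chloro the better of the two. On these data alone, whether an amine, a methoxy group or a fluoro group here would do better or worse stays open, as does the effect of the same exchange elsewhere on the core. Nothing measured here explains the difference.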